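Adding 2-methylphenyl to a compound at the limit

The source may report more compounds than this note shows. Statements on the series, on what has been measured and on what is new or still open speak of the compounds shown alone.

In a functional assay on PC-3 cells (Homo sapiens) for inhibition, read by WST assay, with a stated time of 48 h (on this read-out higher numbers stand for weaker inhibition of growth and lower numbers for stronger inhibition of growth), compound 2 (`C=C(C)C(=O)N(C)C(=O)/C=C/c1cc(OC)c(OC)c(OC)c1`) gives > 10000 nM as a limit of the assay. Compound 1 (`C=C(C)C(=O)N(Cc1cccc(Br)c1)C(=O)/C=C/c1cc(OC)c(OC)c(OC)c1`) gives > 10000 nM as a limit too. Compound 3 (`C=C(C)C(=O)N(Cc1ccccc1C)C(=O)/C=C/c1cc(OC)c(OC)c(OC)c1`) carries 2-methylphenyl in place of hydrogen on a saturated chain carbon bound to an amide-type nitrogen. Among the measured compounds shown here, the one measured step bearing on this is a step that the two limits leave unreadable from compound 1 to compound 2 with 3-bromophenyl leaving that place. Both values stand at the limit of > 10000 nM in this assay, at which 2 of the 2 values shown sit, so no readable step is expected in this assay in either direction. What is expected is a step that the limit leaves unreadable from compound 2 to compound 3 and nothing larger. For compound 3 the estimate is 12000 nM with 5000 nM to 25000 nM as its expected range.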

Compound 3, concentration for 50% growth inhibition: > 10000 nM
Compound 3 was reported as a limit (the forecaster's own chance of this, stated with the estimate: 75%); the middle value lies beyond the limit too.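

In this assay, compound 1, compound 2 and compound 3 all remain limits, so no step among them can be read: the limit of > 10000 nM in this assay, at which 3 of the 3 values shown sit.

The compounds shown leave open whether any group at this place gives a readable growth-inhibition value.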